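Amino for hydrogen on the fused ring of compound 1

A few compounds are considered here, and "the series" means these few. Any claim that something is new, unique, unknown or untested is made for them only; others in the source may bear on it.

Compound 1 `CCn1cc(-c2nc3ccccc3[nH]2)c(=O)c2cc(F)c(N3CCNCC3)cc21` stands in a functional assay on HT-29 cells (Homo sapiens) for cytotoxicity, read by sulforhodamine B assay, with a stated time of 48 h (a lower number here means a stronger inhibitor of growth, a higher number a weaker inhibitor of growth), only at a limit, giving > 10000 nM. That is the limit of > 10000 nM in this assay, at which 1 of the 2 values shown sits, so no number is known for compound 1. Among the compounds with values here, compound 2 `CCn1cc(-c2nc3ccc([N+](=O)[O-])cc3[nH]2)c(=O)c2cc(F)c(N3CCNC(C)C3)c(F)c21` gives 4200 nM in this assay, but compound 2 differs from compound 1 in several places at once and so supports no single step. Compound 3 `CCn1cc(-c2nc3ccc(N)cc3[nH]2)c(=O)c2cc(F)c(N3CCNCC3)cc21` carries amino in place of hydrogen on an aromatic carbon. Within the data shown here, no measured pair isolates this change, so a modest gain in this assay is expected at most, possibly none beyond the scatter. For compound 3 the expected value in this assay is 7000 nM, in the range 2500 nM to 20000 nM. The step from compound 1 to compound 3 is expected as an at least 1.4-fold lower number from compound 1 to compound 3 (0.15 log units; that floor lies within the scatter).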

Compound 3, concentration for 50% growth inhibition: > 10000 nM
Compound 3 gave a limit, no number (the forecaster's own chance of this, stated with the estimate: 45%); middle value at least 1.4-fold (0.15 log units) from the limit.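

Within the data shown here, compound 1 and compound 3 both stand at a limit, so no step between them can be read: the limit of > 10000 nM in this assay, at which 2 of the 3 values shown sit. As far as these compounds go, whether amino in place of hydrogen on an aromatic carbon changes the read-out in this assay at all stays open.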